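Bromo in Place of Methyl on the Aryl Ring of Compound 1

The source may report more compounds than this note shows. Statements on the series, on what has been measured and on what is new or still open speak of the compounds shown alone.

Among the measured compounds shown here, compound 1 `COc1cc(C(=O)c2sc(-c3ccc(C)cc3)cc2N)cc(OC)c1OC` gives 16 nM in a functional assay on MOLT-4 cells (Homo sapiens) for antiproliferative activity (a lower number here means a stronger inhibitor, a higher number a weaker inhibitor), the lowest of the two numbers measured so far, though its nearest neighbour lies within the scatter. That neighbour, compound 2 `COc1ccc(-c2cc(N)c(C(=O)c3cc(OC)c(OC)c(OC)c3)s2)cc1`, gives 18 nM in this assay. The step of a 1.1-fold higher number from compound 1 to compound 2 (0.05 log units; within the scatter) shows that replacing the methyl group of compound 1 left the read-out essentially unchanged.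

Compound 3 `COc1cc(C(=O)c2sc(-c3ccc(Br)cc3)cc2N)cc(OC)c1OC` has not yet been measured. It differs from compound 1 in one respect: bromo in place of methyl on an aromatic carbon

For the measured compounds named here, only one measured step touches this exchange, the one from compound 1 to compound 2, and it stayed within the scatter; it swapped the same methyl for methoxy rather than for bromo, so the guidance is indirect. The expectation is therefore no change beyond the scatter, a 1.1-fold higher number from compound 1 to compound 3 (0.05 log units; within the scatter). Compound 3 is estimated at 18 nM, within a range from 8 nM to 40 nM.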

Compound 3, half-maximal inhibitory concentration: 92 nM
Compound 3: the middle estimate sits 5.1-fold (0.71 log units) below what was measured; measured number outside the range, above it.
By their numbers in this assay, from the lowest: compounds 1 and 2 (each within the scatter of the next); then compound 3.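

In this assay, the position para to a large group proves not to accept every small substituent alike: bromo in place of methyl gives a 5.8-fold higher number from compound 1 to compound 3 (0.76 log units; beyond the scatter) and bromo in place of methoxy gives a 5.1-fold higher number from compound 2 to compound 3 (0.71 log units; beyond the scatter) on the same ring carbon. Methyl and methoxy had stayed within the scatter of each other, so that pair alone gave no sign of any sensitivity here, and bromo is the first group shown to separate from both. Nothing available explains why bromo stands apart from these two groups.

The compounds shown leave open whether fluoro or chloro at this position would stay with methyl and methoxy or fall with bromo. They also leave open where a longer chain such as ethyl or propyl would stand in this series.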